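The source may hold more compounds than are shown below. What is called first, only, known or untested is meant among the compounds shown, and "the series" means these compounds.

Two compounds built on one shared core have been examined in a functional assay on the whole organism (blood, strain Wistar-Okamoto) with Rattus norvegicus as the target, with a stated time of 5 days; a higher number here means that more compound is needed for the effect, a lower number that less compound is needed. Compound 1 `CCC(C)C(C)/N=C(\NC#N)Nc1ccncc1` gives 8 mg/kg. Compound 2 `N#CN/C(=N\Cc1ccccc1)Nc1ccncc1` gives 5 mg/kg. Compound 2 holds the lower of these two numbers, yet its gap to compound 1 lies within the usual scatter of repeated measurements, so the two cannot be ranked against each other on this evidence.

Compound 3 `CC(/N=C(\NC#N)Nc1ccncc1)c1ccccc1` has not yet been measured in this assay. It differs from compound 2 in a single spot: methyl in place of hydrogen on a saturated chain carbon bound to an aromatic carbon and a double-bonded nitrogen. Within the data shown here, no measured pair in this small set shows a change of this kind, so the data give no direction for it. The step expected from this change, no change at the digits printed from compound 2 to compound 3 (within the scatter), is none beyond the scatter. Compound 3 is therefore estimated at 5 mg/kg, with a likely range from 2.5 mg/kg to 10 mg/kg.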

Compound 3, minimum effective dose: 10 mg/kg
Compound 3: middle estimate off by 2.0-fold (0.30 log units), on the low side; the range from low to high includes it.
By their numbers in this assay, from the lowest: compounds 2, 1 and 3 (each within the scatter of the next).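

Methyl in place of hydrogen on a saturated chain carbon bound to an aromatic carbon and a double-bonded nitrogen gives a 2.0-fold higher number from compound 2 to compound 3 (0.30 log units; within the scatter) in this assay, so this first reading of the change shows no effect that can be told apart from the scatter. The swap of phenyl in place of sec-butyl, on a saturated chain carbon bound to a double-bonded nitrogen and a saturated chain carbon, gives a 1.3-fold higher number from compound 1 to compound 3 (0.10 log units; within the scatter) and likewise stays inside the scatter. No measurement at hand offers an explanation for either step.

One methyl step cannot show whether this carbon tolerates other groups. An ethyl group, a hydroxyl group or a longer chain at this carbon could still give a step beyond the scatter.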